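A few compounds are considered here, and "the series" means these few. Any claim that something is new, unique, unknown or untested is made for them only; others in the source may bear on it.

Measured so far in a functional assay on the whole organism (strain Wister albino) for inhibition, with Rattus norvegicus as the target, read by paw edema, with stated times of 30 min and 3 h, at a dose of 10 mg/kg by the oral route; a lower number here means less inhibition, a higher number more inhibition at the dose given (going by the name of the read-out):

- compound 1, `CC(C)Cc1ccc(C(C)c2nn(CN3CCN(c4cccc(Cl)c4)CC3)c(=S)o2)cc1`, gives 64.3%
- compound 2, `CC(C)Cc1ccc(C(C)c2nn(CN3CCN(c4ccc([N+](=O)[O-])cc4)CC3)c(=S)o2)cc1`, gives 75.1%
- compound 3, `CSc1ccc(Cc2nn(CN3CCN(c4cccc(Cl)c4)CC3)c(=S)o2)cc1`, gives 74.7%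

Compound 1 and compound 2 share one core and differ only by 4-nitrophenyl in place of 3-chlorophenyl on an amine nitrogen in a ring; this change brought a number 10.8 percentage points higher from compound 1 to compound 2 (beyond the scatter). Compound 3 has a different core; how the cores of compound 1 and compound 3 differ is not broken down here. Compound 4, `CSc1ccc(Cc2nn(CN3CCN(c4ccc([N+](=O)[O-])cc4)CC3)c(=S)o2)cc1`, differs from compound 3 by 4-nitrophenyl in place of 3-chlorophenyl on an amine nitrogen in a ring, the same change at the same place. For the measured compounds named here, the only measured example of it is the step from compound 1 to compound 2, so the expectation rests on one pair. Going by the values given here, on that basis compound 4 is expected to rise by about a number 7.3 percentage points higher from compound 3 to compound 4 (within the scatter), a step of similar size to the earlier one, though the single example leaves the size uncertain. Compound 4 is estimated at 82%, most likely between 72% and 91%.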

Compound 4, a percentage reported as inhibition, in the whole organism at one dose (the size of the read-out at that dose, not a potency): 56.6%
Beside the measured number, compound 4's estimate is 25.4 percentage points above it; measured number outside the range, below it.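

In this assay, putting 4-nitrophenyl in place of 3-chlorophenyl on an amine nitrogen in a ring gave a number 18.1 percentage points lower from compound 3 to compound 4 (beyond the scatter), so the change did not carry over from one core to the other, and its direction reversed: the same change on two cores in this assay, a number 10.8 percentage points higher (beyond the scatter) from compound 1 to compound 2 and a number 18.1 percentage points lower (beyond the scatter) from compound 3 to compound 4, 28.9 percentage points apart, beyond the scatter of two such steps

For these two pairs, then, the result of the change on one core was a poor guide to its result on the other. The pairs do not show which feature of the cores decides the direction, nor what the change would do on a third core.

The compounds shown leave open how other groups would behave in this place on both cores, such as a plain phenyl or a 4-methoxyphenyl. They also leave open whether either of those would follow the same reversal.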